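The source may hold more compounds than are shown below. What is called first, only, known or untested is meant among the compounds shown, and "the series" means these compounds.

Three compounds have been measured in an assay on microsomes from liver for inhibition of 3-hydroxy-3-methylglutaryl-coenzyme A reductase (Rattus norvegicus); on this read-out lower numbers stand for stronger inhibition and higher numbers for weaker inhibition:

- compound 1 `CC(C)c1c(C(=O)N2CCCCC2)nn(-c2ccc(F)cc2)c1OC[C@@H](O)C[C@@H](O)CC(=O)O`: 47 nM
- compound 2 `COc1ccc(CNC(=O)c2nn(-c3ccc(F)cc3)c(OC[C@@H](O)C[C@@H](O)CC(=O)O)c2C(C)C)cc1`: 12 nM
- compound 3 `CC(C)c1c(C(=O)NCc2ccccn2)nn(-c2ccc(F)cc2)c1OC[C@@H](O)C[C@@H](O)CC(=O)O`: 25 nM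

Compound 3 stands second highest of the three numbers: its gap to compound 1, a 1.9-fold lower number from compound 1 to compound 3 (0.27 log units; within the scatter), lies within the scatter, while compound 2 is separated from it by a step beyond the scatter, a 2.1-fold higher number from compound 2 to compound 3 (0.32 log units; beyond the scatter). Compound 4 `CC(C)c1c(C(=O)NCc2cccc(Cl)c2)nn(-c2ccc(F)cc2)c1OC[C@@H](O)C[C@@H](O)CC(=O)O` differs from compound 3 in one place: 3-chlorophenyl in place of pyridin-2-yl on a saturated chain carbon bound to an amide-type nitrogen. Among the compounds with values here, the step that bears most directly on this change is the one between compound 2 and compound 3, where a carbon-only benzyl carrying a methoxy group gave the lower number and the pyridinyl the higher, a 2.1-fold higher number from compound 2 to compound 3 (0.32 log units; beyond the scatter). The move from a piperidinyl amide to a benzyl-type amide, a 3.9-fold lower number from compound 1 to compound 2 (0.59 log units; beyond the scatter), points the same way. Since compound 4 returns to a carbon-only ring, a modest step toward a lower number is expected, of about a 1.8-fold lower number from compound 3 to compound 4 (0.25 log units; within the scatter). Compound 4 is therefore estimated at 14 nM in this assay , with a range from 6 nM to 35 nM.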

Compound 4, half-maximal inhibitory concentration: 5.4 nM
Compound 4: middle estimate off by 2.6-fold (0.41 log units), on the high side; the whole stated range lies above it.
By their numbers in this assay, from the lowest: compound 4; then compound 2; then compounds 3 and 1 (each within the scatter of the next).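

In this assay, 3-chlorophenyl on the saturated chain carbon bound to an amide-type nitrogen gives the lowest number yet, with a 4.6-fold lower number from compound 3 to compound 4 (0.67 log units; beyond the scatter) against pyridin-2-yl. It also improves on the carbon-only 4-methoxyphenyl, with a 2.2-fold lower number from compound 2 to compound 4 (0.35 log units; beyond the scatter), so having a ring of carbon only does not by itself set the number at this position. Against the piperidin-1-yl amide, (3-chlorobenzyl)amino gives an 8.7-fold lower number from compound 1 to compound 4 (0.94 log units; beyond the scatter), the largest step among these compounds.

No measurement shown here bears on what lies behind these steps. The compounds shown leave open whether the chlorine or its place on the ring carries the gain, and whether phenyl, 3-fluorophenyl or 3-methylphenyl on the same chain carbon would give a number near that of compound 4.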